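Para substituent swap on the shared core: fluoro to methyl

The compounds below may be only part of what the source reports. "The series", "measured", "known", "first", "only" and "open" are said of these compounds alone.

Compound 2 `Cn1cnnc1SCC(=O)N/N=c1/scc(-c2ccc(F)cc2)n1-c1ccccc1` stands lowest of the two numbers recorded in an ADME assay on NIH3T3 cells (Mus musculus) for cytotoxicity, read by MTT assay, with a stated time of 24 h; a higher number here means a weaker inhibitor, a lower number a stronger inhibitor. Compound 1 `COc1ccc(-c2cs/c(=N/NC(=O)CSc3nncn3C)n2-c2ccccc2)cc1` is its nearest neighbour; in this assay compound 1 gives 167 ug/mL, while compound 2 gives 65 ug/mL. Among the compounds with values here, the only measured step between them, a 2.6-fold lower number from compound 1 to compound 2 (0.41 log units; beyond the scatter), therefore shows that a change at this position of the shared core can move the number beyond the scatter, though only modestly.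

Compound 3 `Cc1ccc(-c2cs/c(=N/NC(=O)CSc3nncn3C)n2-c2ccccc2)cc1` has not yet been measured in this assay. It differs from compound 2 in one place: methyl in place of fluoro on an aromatic carbon. Within the data shown here, no measured pair shows this particular exchange, so the one step at the same position is all that bears on it. Since that step was modest, the author expects the step of a 1.5-fold higher number from compound 2 to compound 3 (0.16 log units; within the scatter) to be small as well, most likely a somewhat higher number than compound 2 but quite possibly within the scatter. The estimate for compound 3 in this assay is 95 ug/mL, with a range from 40 ug/mL to 220 ug/mL.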

Compound 3, half-maximal inhibitory concentration: 130 ug/mL
Estimate against measurement, compound 3: 1.4-fold (0.14 log units) below; measured number inside the range.
By their numbers in this assay, from the lowest: compounds 2, 3 and 1 (each within the scatter of the next, the first and the last beyond it).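

In this assay, putting methyl in place of fluoro gives a 2.0-fold higher number from compound 2 to compound 3 (0.30 log units; within the scatter) and putting methyl in place of methoxy gives a 1.3-fold lower number from compound 1 to compound 3 (0.11 log units; within the scatter) and so neither exchange at this position moves the number beyond the scatter. The methyl compound therefore cannot be separated from either of the other two, even though the fluoro and methoxy compounds are separated from each other, so the earlier step does not divide these three groups into two clear levels and the change at this position looks less decisive than that single step alone could suggest. Nothing available here bears on what lies behind these small differences.

Three small groups on one aromatic carbon leave open whether an amine, a carboxylic acid or a longer chain at the same place would carry the number clearly outside this narrow span. They also leave open whether the same exchanges would behave alike with a different group elsewhere on the shared core.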